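Aryl group exchange on the ring amine of the shared core

The source may report more compounds than this note shows. Statements on the series, on what has been measured and on what is new or still open speak of the compounds shown alone.

Working notes on the series. Going by the values given here, compound 1 `Clc1cccc(N2CCN(CCCCNc3nc(NCc4ccco4)c4ccccc4n3)CC2)c1Cl` is the only member with a number in a functional assay on MCF7 cells (Homo sapiens) for cytotoxicity, read by MTT assay, with a stated time of 2 days; a higher number here means a weaker inhibitor, a lower number a stronger inhibitor: in that assay compound 1 gives 2970 nM. Compound 2 `CCN(CC)CCNc1nc(NCc2ccco2)c2ccccc2n1` carries a different chain on the shared core; in this assay compound 2 gives "not determined" (no result reported), so no number stands beside it and it offers no comparison. Compound 1 therefore stands alone on the numbers shown, with nothing to rank it against.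

Compound 3 `Cc1cccc(N2CCN(CCCCNc3nc(NCc4ccco4)c4ccccc4n3)CC2)c1C` differs from compound 1 in one place: 2,3-dimethylphenyl in place of 2,3-dichlorophenyl on an amine nitrogen in a ring. The ring amine, its chain and the shared core are kept. Among the compounds with values here, no step between measured compounds covers this kind of change, so the size of its effect in this assay cannot be read from the data. The expectation is a step of a 1.2-fold higher number from compound 1 to compound 3 (0.07 log units; within the scatter) of modest size, in no settled direction, most likely inside the usual scatter. Compound 3 is accordingly estimated at 3500 nM in this assay, with a range from 1200 nM to 10000 nM.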

Compound 3, half-maximal inhibitory concentration: 3140 nM
Estimate against measurement, compound 3: 1.1-fold (0.05 log units) above, within the range that was stated.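

In this assay, going by these compounds alone, 2,3-dimethylphenyl in place of 2,3-dichlorophenyl on the amine nitrogen in the ring gives a 1.1-fold higher number from compound 1 to compound 3 (0.02 log units; within the scatter), the first step that can be read at this position. The two chlorine atoms of the leaving group give way to two carbon atoms, while the heavy-atom count, the aromatic ring and the absence of hydrogen-bond donors and acceptors stay as they were, and compound 1 and compound 3 cannot be told apart in this assay. This holds for this one pair only and gives no rule for other aryl groups at this position, and no measurement of any property of the two groups accompanies the result, so nothing can be said about why the exchange leaves the reading within the scatter.

Both aryl groups shown are 2,3-disubstituted phenyl rings, so it remains open how an unsubstituted phenyl, a methoxyphenyl, a pyridyl or an aryl group carrying a carboxylic acid would read at this position. Steps involving compound 2 cannot be read, which leaves open what the ring amine and the butyl-length chain contribute compared with a diethylamino chain on the shared core.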